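The source may hold more compounds than are shown below. What is called first, only, known or untested is meant among the compounds shown, and "the series" means these compounds.

Compound 3 `Clc1ccccc1-c1nc(NCc2ccc(-c3cccnc3)cc2)c2ccccc2n1` stands second highest of the three numbers in an assay on a protein complex for inhibition of ubiquitin carboxyl-terminal hydrolase 1/WD repeat-containing protein 48 (Homo sapiens), read by fluorescence (on this read-out lower numbers stand for stronger inhibition and higher numbers for weaker inhibition), giving 2100 nM. Its nearest neighbour is compound 2 `FC(F)c1ccccc1-c1nc(NCc2ccc(-c3cccnc3)cc2)c2ccccc2n1`, which gives 1400 nM; the step of a 1.5-fold higher number from compound 2 to compound 3 (0.18 log units; within the scatter) lies within the scatter, so no order between these two can be read. Compound 1 `O=[N+]([O-])c1ccccc1-c1nc(NCc2ccc(-c3cccnc3)cc2)c2ccccc2n1` gives 7800 nM, and the steps of a 5.6-fold lower number from compound 1 to compound 2 (0.75 log units; beyond the scatter) and a 3.7-fold lower number from compound 1 to compound 3 (0.57 log units; beyond the scatter) are the only ones beyond the scatter. Compound 4 `c1cncc(-c2ccc(CNc3nc(N4CCCC4)nc4ccccc34)cc2)c1` differs from compound 3 by pyrrolidin-1-yl in place of 2-chlorophenyl on an aromatic carbon, on an aromatic carbon of the shared core between two ring nitrogen atoms. Going by the values given here, none of the measured steps bears directly on this change: all three vary only the substituent on the ring that now leaves altogether, so nothing measured speaks to the exchange of an aromatic ring for pyrrolidin-1-yl. Among the compounds with values here, with no precedent, the expected step of a 1.4-fold higher number from compound 3 to compound 4 (0.15 log units; within the scatter) is set near zero and the range is kept wide. Compound 4 is therefore estimated at 3000 nM in this assay, with a range from 500 nM to 20000 nM.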

Compound 4, half-maximal inhibitory concentration: "not active" (no number reported)
Compound 4 has no reported number here, and the estimate cannot be compared.
By their numbers in this assay, from the lowest: compounds 2 and 3 (each within the scatter of the next); then compound 1.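

Going by these compounds alone, compound 4 is reported as not active in this assay with no number, so no step from compound 3 to compound 4 can be read. No evidence at hand bears on this result. The compounds shown leave open whether any non-aromatic group at this place on the shared core can give a measurable number.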